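One Aryl Ether Swap at the Far End of a Long Linker

This account rests on a few compounds, and the source may have more. Where it says the series, first, only, none or still open, it means among the compounds named here.

Compound 1 `Cc1nn(C)c(Oc2ccc(I)cc2)c1/C=N\CCCCCOc1cc2oc(=O)cc(C)c2cc1Cl`: in a functional assay on U-87MG ATCC cells for antiproliferative activity against U-87 MG (Homo sapiens), read by MTT assay, with a stated time of 72 h (on this read-out higher numbers stand for weaker inhibition and lower numbers for stronger inhibition), compound 1 gives > 25000 nM, which is a limit of the assay rather than a number.
Compound 2 `Cc1ccc(Oc2c(/C=N\CCCCCOc3cc4oc(=O)cc(C)c4cc3Cl)c(C)nn2C)cc1`: in this assay compound 2 gives 7970 nM.
Compound 3 `Cc1nn(C)c(Oc2cccc(F)c2)c1/C=N\CCCCCCOc1cc2oc(=O)cc(C)c2cc1Cl`: in this assay compound 3 gives > 25000 nM, again a limit rather than a number.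

Compound 3 therefore stands at the upper edge of what this assay can report; (the limit of > 25000 nM in this assay, at which 2 of the 3 values shown sit), so it shares that position with compound 1, and only compound 2 yields an actual number. Compound 4 `Cc1nn(C)c(Oc2ccccc2Br)c1/C=N\CCCCCCOc1cc2oc(=O)cc(C)c2cc1Cl` has not yet been measured. It differs from compound 3 by 2-bromophenyl in place of 3-fluorophenyl on an oxygen on an aromatic ring. Among the compounds with values here, the only measured step, an at least 3.1-fold lower number from compound 1 to compound 2 (0.49 log units; beyond the scatter), also alters a substituent on that phenyl ring, replacing a halogen with a methyl group. The change from compound 3 to compound 4 keeps a halogen but exchanges one for another, so that step offers only a loose guide, and nothing shown distinguishes one halogen-bearing phenyl from another. The step of a number no higher from compound 3 to compound 4 (the limit leaves the size open) is expected to stay within the scatter. Compound 4 is estimated at 25000 nM in this assay, with a range from 8000 nM to 60000 nM, and a fair chance that it, too, returns only a limit.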

Compound 4, half-maximal inhibitory concentration: 21800 nM
Compound 4: middle estimate off by 1.1-fold (0.06 log units), on the high side, and the stated range covers the measured number.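

As far as these compounds go, at this position, the aryl group on the oxygen, putting 2-bromophenyl in place of 3-fluorophenyl gives an at least 1.1-fold lower number from compound 3 to compound 4 (0.05 log units; that floor lies within the scatter), so the data show no real difference between the two groups, and the true size of the step stays unknown. What this result adds is that a halogen-bearing phenyl here can give an actual number: in this assay, compound 4 gives 21800 nM, a value that can anchor later comparisons on this chain. Compound 1 and compound 3, which also carry a halogen on this phenyl ring, go against any broader reading, as each remains at a limit rather than a number: the limit of > 25000 nM in this assay, at which 2 of the 4 values shown sit.

The bromine and fluorine differ in both identity and ring position between compound 3 and compound 4, so the halogen's identity cannot be separated from where it sits. From the compounds shown here alone, how this read-out would respond to a phenyl ring carrying an amine or a carboxylic acid, groups unlike the halogens and the methyl seen so far, also remains open.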